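Amide substituent change on the fluorinated indanylidene acetamide series

The source may hold more compounds than are shown below. What is called first, only, known or untested is meant among the compounds shown, and "the series" means these compounds.

Compound 1 `O=C(/C=C1\CCc2ccc(F)cc21)NCCO` carries a 2-hydroxyethyl group on the amide nitrogen. Among the compounds with values here, in a functional assay on the whole organism with Rattus norvegicus as the target, at a dose of 20 mg/kg by the oral route (a lower number here means less inhibition, a higher number more inhibition at the dose given (going by the name of the read-out)), compound 1 gives 78%, the highest of the three numbers so far, and both gaps to the other compounds lie beyond the usual scatter. Compound 2 `NC(=O)/C=C1\CCc2cc(F)cc(F)c21` is the primary amide on a differently fluorinated core; in this assay compound 2 gives 55%. Compound 3 `O=C(/C=C1\CCc2c(F)cc(F)cc21)NC1CC1`, a cyclopropyl amide on yet another fluorination pattern, gives 28% in this assay. Neither compound 2 nor compound 3 differs from compound 1 in a single place, so no clean step can be read between them.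

Compound 4 `CC(C)NC(=O)/C=C1\CCc2ccc(F)cc21` keeps the core of compound 1 and differs only as follows: isopropyl in place of 2-hydroxyethyl on an amide-type nitrogen. In this assay the step from compound 1 to compound 4 is expected to be a modest decrease, around the edge of the scatter, as a number 15 percentage points lower from compound 1 to compound 4 (beyond the scatter). The expectation leans downward because compound 3 gives 28% in this assay, and that other amide without a hydroxyl on the nitrogen falls well under compound 1. Compound 4 is therefore estimated at 63%, within a range from 40% to 82%.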

Compound 4, a percentage reported as inhibition, in the whole organism at one dose (the size of the read-out at that dose, not a potency): 71%
Compound 4: middle estimate off by 8 percentage points, on the low side; low and high end bracket the measured number.
By their numbers in this assay, from the lowest: compound 3; then compound 2; then compounds 4 and 1 (each within the scatter of the next).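

In this assay, within the data shown here, the step of a number 7 percentage points lower from compound 1 to compound 4 (within the scatter) is the first comparison that differs in one place, isopropyl in place of 2-hydroxyethyl on an amide-type nitrogen. On the core of compound 1 at this one dose, the hydroxyl with its hydrogen-bond donor and acceptor can therefore be replaced by an all-carbon group of the same heavy-atom count without a difference beyond the scatter. Nothing measured here bears on this result.

Steps to compound 2 and compound 3 cannot be read, as the amide group and the fluorination pattern differ together in them, so the role of fluorine placement stays open. Also open, as far as these compounds go, is how a longer chain, an amine or a carboxylic acid on this nitrogen would read on the core of compound 1.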